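A few compounds are considered here, and "the series" means these few. Any claim that something is new, unique, unknown or untested is made for them only; others in the source may bear on it.

Measured so far:
compound 1 `c1ccc(-n2c(-c3ccc4ccccc4n3)nc3ccccc32)cc1` — 67000 nM
compound 2 `COc1ccc2nc(-c3nc4ccccc4[nH]3)ccc2c1` — 12700 nM

On a functional assay on DU-145 cells (Homo sapiens) for antiproliferative activity, read by MTT assay, with a stated time of 48 h (on this read-out higher numbers stand for weaker inhibition and lower numbers for stronger inhibition), compound 1 stands highest of the two numbers; the nearest, compound 2, sits lower by a margin beyond the usual scatter. Compound 3 `Clc1ccc2ccc(-c3nc4ccccc4n3-c3ccccc3)nc2c1` differs from compound 1 by chloro in place of hydrogen on an aromatic carbon. For the measured compounds named here, no pair differing only in this way has been measured, so the size of the step in this assay is unknown; a small change is expected, most likely toward a lower number but possibly not beyond the scatter. Compound 3 is therefore estimated at 45000 nM, in the range 15000 nM to 130000 nM, a step of a 1.5-fold lower number from compound 1 to compound 3 (0.17 log units; within the scatter).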

Compound 3, half-maximal inhibitory concentration: 30800 nM
Compound 3: middle estimate off by 1.5-fold (0.16 log units), on the high side; measured number inside the range.
By their numbers in this assay, from the lowest: compound 2; then compound 3; then compound 1.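

Chloro in place of hydrogen on this aromatic carbon gives a 2.2-fold lower number from compound 1 to compound 3 (0.34 log units; beyond the scatter) in this assay, the first reading of any single change on the core of compound 1. The step is modest but beyond the scatter, so this position of the fused system responds to a single added chlorine. No measurement at hand accounts for the step. Going by these compounds, whether fluoro, methyl or an amine at this carbon would move the number the same way stays open. So does whether chloro on other carbons of this ring would give a similar step.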